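Trading a Phenoxy Group for Dimethylamino

The source may report more compounds than this note shows. Statements on the series, on what has been measured and on what is new or still open speak of the compounds shown alone.

Measured in a functional assay on COLO 205 cells (Homo sapiens) for inhibition, read by sulforhodamine B assay, with a stated time of 48 h; on this read-out higher numbers stand for weaker inhibition of growth and lower numbers for stronger inhibition of growth:
compound 1, `COc1cc(C)cc(-c2nn(CC#N)cc2-c2ccc(-c3cccc(C(C)=O)c3)nc2)c1`, gives 4130 nM;
compound 2, `Cc1cc(O)cc(-c2nn(CC#N)cc2-c2ccnc(-c3ccc(Oc4ccccc4)cc3)c2)c1`, gives 3260 nM.

Compound 2 has the lower of the two numbers, but its nearest neighbour is compound 1 and the gap between them lies within the scatter of this assay, so the two are not separated on the measurements shown. For the measured compounds named here, the two compounds differ at several places at once, and no single step between them can be read.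

Compound 3, `Cc1cc(O)cc(-c2nn(CC#N)cc2-c2ccnc(-c3ccc(N(C)C)cc3)c2)c1`, departs from compound 2 by a single change: dimethylamino in place of phenoxy on an aromatic carbon. Going by the values given here, no measured pair shows what this exchange does in this assay. Compound 3 is therefore expected to stay close to compound 2, with a step of a 1.1-fold higher number from compound 2 to compound 3 (0.03 log units; within the scatter) that is not expected to exceed the scatter. The value of compound 3 is estimated at 3500 nM, within a range from 1200 nM to 10000 nM.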

Compound 3, concentration for total growth inhibition: 4130 nM
Compound 3: the middle estimate sits 1.2-fold (0.07 log units) below what was measured; the range from low to high includes it.
By their numbers in this assay, from the lowest: compounds 2, 1 and 3 (each within the scatter of the next).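

In this assay, for the compounds shown here, dimethylamino in place of phenoxy gives a 1.3-fold higher number from compound 2 to compound 3 (0.10 log units; within the scatter), the first step that can be read at this place on an aromatic carbon, para to a large group. The group that leaves has 7 heavy atoms and a six-membered aromatic ring of carbon only, while the group that enters has 3 heavy atoms and no ring, so on this read-out compound 3 is not separated from compound 2 even without that ring. No other measurement bears on this result, and nothing shown explains it.

The compounds shown leave open whether a carboxylic acid or a primary amine at this same place would separate from compound 2 beyond the scatter. They also leave open whether a longer chain on the nitrogen of the dimethylamino group would do so.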